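This account rests on a few compounds, and the source may have more. Where it says the series, first, only, none or still open, it means among the compounds named here.

Working notes on the series. Compound 1 `C=CCNC(=S)N/N=C1\C(=O)Nc2ccccc21` gives 26100 nM in a functional assay on KB 3-1 cells (Homo sapiens) for cytotoxicity, read by MTT assay, with a stated time of 72 h; on this read-out higher numbers stand for weaker inhibition and lower numbers for stronger inhibition. For the measured compounds named here, compound 2 `O=C1Nc2ccccc2/C1=N/NC(=S)Nc1ccc(F)cc1` gives 14200 nM in this assay and stands lowest of the two numbers so far, with compound 1 nearest; the step of a 1.8-fold lower number from compound 1 to compound 2 (0.26 log units; within the scatter) lies within the scatter, so no order between them is claimed. Compound 3 `CC(C)(C)c1ccc(NC(=S)N/N=C2\C(=O)Nc3ccccc32)cc1` is not yet measured in this assay. It differs from compound 2 by tert-butyl in place of fluoro on an aromatic carbon. Going by the values given here, no measured step touches this position; the only step available, a 1.8-fold lower number from compound 1 to compound 2 (0.26 log units; within the scatter), altered the group on the amide-type nitrogen and stayed within the scatter, so it gives no indication of direction here. For compound 3 the expectation is therefore a number close to that of compound 2, with no step beyond the scatter in either direction, expressed as an expected step of a 1.2-fold lower number from compound 2 to compound 3 (0.07 log units; within the scatter). Compound 3 is estimated at 12000 nM, with a range of 4000 nM to 36000 nM.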

Compound 3, half-maximal inhibitory concentration: 8130 nM
Compound 3: the middle estimate sits 1.5-fold (0.17 log units) above what was measured; measured number inside the range.
By their numbers in this assay, from the lowest: compounds 3, 2 and 1 (each within the scatter of the next, the first and the last beyond it).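

For the compounds shown here, at this aromatic carbon, para to a large group, tert-butyl in place of fluoro gives in this assay a 1.7-fold lower number from compound 2 to compound 3 (0.24 log units; within the scatter), the first measured reading at this position. An entering group of 4 heavy atoms in place of 1 therefore leaves the number within the scatter, so compound 2 and compound 3 cannot be placed in any order, and this position accepts both groups without a step that can be read as a real change. No measurement on hand bears on the reason for this result.

Open, on these data alone, is whether an amine or a carboxylic acid on this same carbon would give a step beyond the scatter. Also open, as far as these compounds go, is whether a longer alkyl chain or a methoxy group here would do so.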